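Bromo for isopropyl on the aryl arm of compound 2

The source may hold more compounds than are shown below. What is called first, only, known or untested is meant among the compounds shown, and "the series" means these compounds.

Three compounds of the shared core have numbers in a functional assay on ECa-109 cells (Homo sapiens) for inhibition, read by MTT assay, with a stated time of 72 h; a lower number here means a stronger inhibitor, a higher number a weaker inhibitor. Compound 1 `N#Cc1c(Nc2ccccc2F)nc(SCc2cn(Cc3ccccc3Cl)nn2)nc1-c1ccccc1` gives 23000 nM. Compound 2 `Cc1ccc(Nc2nc(SCc3cn(Cc4ccccc4Cl)nn3)nc(-c3ccc(C(C)C)cc3)c2C#N)cc1` gives 5080 nM. Compound 3 `COc1ccc(Nc2nc(SCc3cn(Cc4ccccc4Cl)nn3)nc(-c3ccc(C(C)C)cc3)c2C#N)cc1` gives 3580 nM. Compound 2 stands second highest of the three numbers: compound 3 lies nearest, within the scatter, and compound 1 furthest, with a higher number beyond the scatter. Within the data shown here, the one single-place step known is a 1.4-fold lower number from compound 2 to compound 3 (0.15 log units; within the scatter), a change on the anilino ring, not on the aryl arm.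

Compound 4 `Cc1ccc(Nc2nc(SCc3cn(Cc4ccccc4Cl)nn3)nc(-c3ccc(Br)cc3)c2C#N)cc1` differs from compound 2 in one place: bromo in place of isopropyl on an aromatic carbon. Among the measured compounds shown here, no measured step touches this group. For the measured compounds named here, compound 1 carries an unsubstituted phenyl at this arm but also differs at the anilino ring, so its value and that of compound 2 show only that the doubly changed compound is weaker; no single step can be read from them. For compound 4 a modest weakening is expected, a 1.6-fold higher number from compound 2 to compound 4 (0.20 log units; within the scatter). Compound 4 is estimated at 8000 nM, within 2500 nM to 25000 nM.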

Compound 4, half-maximal inhibitory concentration: 3090 nM
Beside the measured number, compound 4's estimate is 2.6-fold (0.41 log units) above it; low and high end bracket the measured number.
By their numbers in this assay, from the lowest: compounds 4, 3 and 2 (each within the scatter of the next); then compound 1.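

Among these compounds, the one step on the aryl arm in this assay is a 1.6-fold lower number from compound 2 to compound 4 (0.22 log units; within the scatter) and lies within the scatter, so exchanging 4-isopropylphenyl for 4-bromophenyl, with three carbons leaving and one bromine entering, gives no separable difference at this position. The arm now has a single-place reading of its own, and it resembles the anilino-ring step a 1.4-fold lower number from compound 2 to compound 3 (0.15 log units; within the scatter) in that neither goes beyond the scatter. No measurement on hand explains this result.

From the compounds shown here alone, whether an amine, a carboxylic acid or a longer alkyl chain on this aromatic carbon would give a step beyond the scatter remains open. Compound 1 differs from the others in more than one place, so the separate contributions of its unsubstituted phenyl and its anilino ring cannot be read.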